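The source may report more compounds than this note shows. Statements on the series, on what has been measured and on what is new or still open speak of the compounds shown alone.

Measured so far in a functional assay on the whole organism (strain ICR) for inhibition, with Mus musculus as the target, with stated times of 7 days and 0.5 h, at a dose of 10 umol/kg by the intraperitoneal route; a lower number here means less inhibition, a higher number more inhibition at the dose given (going by the name of the read-out):
- compound 1, `CC(=O)N1CCC(c2ccc(-c3cc(C(=O)O)cc4cc(-c5ccc(C(F)(F)F)cc5)ccc34)cc2)CC1`, 83.3%
- compound 2, `O=C(O)c1cc(-c2ccc(C3CCNCC3)cc2)cc(-c2cn(-c3ccc(C(F)(F)F)cc3)nn2)c1`, 70.7%
- compound 3, `O=C(O)c1cc(O)c2ccc(-c3ccc(C(F)(F)F)cc3)cc2c1`, 23.4%

Compound 1 stands highest of the three; compound 2 lies lower by a margin beyond the scatter, and compound 3 lies far lower still. Going by the values given here, no step between compounds that differ in one place is available, so the size of a single change is not known from the data.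

Compound 4, `C#CCCCCN1CCC(c2ccc(-c3cc(C(=O)O)cc4cc(-c5ccc(C(F)(F)F)cc5)ccc34)cc2)CC1`, is not yet measured. It differs from compound 1 by hex-5-yn-1-yl in place of acetyl on an amine nitrogen in a ring.

Compound 4 is expected to give a value near that of compound 1, with a step of a number 9.3 percentage points lower from compound 1 to compound 4 (within the scatter) that is estimated to be small, at most slightly downward, and may fall within the scatter. The expected value for compound 4 is 74%, in the range 52% to 90%.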

Compound 4, a percentage reported as inhibition, in the whole organism at one dose (the size of the read-out at that dose, not a potency): 52.4%
For compound 4 the middle estimate is 21.6 percentage points above the measured one; the range from low to high includes it.
By their numbers in this assay, from the lowest: compound 3; then compound 4; then compound 2; then compound 1.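

In this assay, going by these compounds alone, hex-5-yn-1-yl in place of acetyl on the amine nitrogen in the six-membered ring gives a number 30.9 percentage points lower from compound 1 to compound 4 (beyond the scatter), the first single-place step. This position is therefore not indifferent to substitution, at least for this pair at the dose given. Nothing measured here accounts for the step.

Open, as far as these compounds go, is whether the carbonyl, the chain length or the triple bond drives the change, which a hexanoyl group or a plain hexyl chain on that nitrogen would separate. Also open, from the compounds shown here alone, is how the free secondary amine compares on the core of compound 1.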